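A few compounds are considered here, and "the series" means these few. Any claim that something is new, unique, unknown or untested is made for them only; others in the source may bear on it.

Of the compounds shown here, three have been measured in a functional assay for agonist activity at G protein-coupled receptor 88 (Homo sapiens), read by HTRF and cAMP accumulation; on this read-out higher numbers stand for an effect only at larger amounts of compound and lower numbers for an effect already at smaller amounts. Compound 1 `CC[C@H](C)[C@H](N)CN(C(=O)[C@@H]1C[C@H]1c1cccc(F)c1)c1ccc(-c2ccccc2)cc1` gives 560 nM, and compound 2 `CC[C@H](C)[C@H](N)CN(C(=O)[C@@H]1C[C@H]1c1cccs1)c1ccc(-c2ccccc2)cc1` gives 360 nM. Within the data shown here, the step of a 1.6-fold lower number from compound 1 to compound 2 (0.19 log units; within the scatter) is the only change between measured compounds that sits in a single place. Compound 3 `CCCc1ccc(-c2ccc(N(C[C@@H](N)[C@@H](C)CC)C(=O)[C@@H]3C[C@H]3c3ccccc3)cc2)cc1` gives 61 nM in this assay, the lowest of the three numbers, and its gaps to compound 1 and to compound 2 both lie beyond the scatter. Compound 4 `CC[C@H](C)[C@H](N)CN(C(=O)[C@@H]1C[C@H]1c1ccccc1)c1ccc(-c2ccc(COC)cc2)cc1` has not been measured. It differs from compound 3 by methoxy in place of ethyl on a saturated chain carbon bound to an aromatic carbon. Among the measured compounds shown here, no measured step touches this part of the molecule: the step from compound 1 to compound 2 concerns the group on a saturated ring carbon, and compounds 1 and 2 differ from compound 3 in two places at once, so their gaps to compound 3 cannot be assigned to the group on the saturated chain carbon alone. The expectation for compound 4 therefore rests on compound 3 with a wide range. For compound 4 a small step upward is expected, a 2.0-fold higher number from compound 3 to compound 4 (0.29 log units; within the scatter). Compound 4 is estimated at 120 nM, within 40 nM to 400 nM.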

Compound 4, half-maximal effective concentration: 35 nM
Compound 4: the middle estimate sits 3.4-fold (0.54 log units) above what was measured; the whole stated range lies above it.
By their numbers in this assay, from the lowest: compounds 4 and 3 (each within the scatter of the next); then compounds 2 and 1 (each within the scatter of the next).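

In this assay, among these compounds, methoxy in place of ethyl on a saturated chain carbon bound to an aromatic carbon gives a 1.7-fold lower number from compound 3 to compound 4 (0.24 log units; within the scatter), the first measured change at this position. On this read-out, 4-propylphenyl and 4-(methoxymethyl)phenyl therefore cannot be told apart: the chain can carry an oxygen, and with it one hydrogen-bond acceptor by count, without a shift beyond the scatter. Nothing available explains why the two groups read alike.

Going by these compounds, it remains open whether a longer chain, an amine or a carboxylic acid at this place would also stay within the scatter of compound 3. On these data alone, it is also open whether the same exchange would read alike with thiophen-2-yl or 3-fluorophenyl on the saturated ring carbon.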